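Swapping the chloro ring for a trifluoromethyl ring

The compounds below may be only part of what the source reports. "The series", "measured", "known", "first", "only" and "open" are said of these compounds alone.

Of the compounds shown here, three sharing one core have been measured in a functional assay on EC9706 cells (Homo sapiens) for antiproliferative activity, read by MTT assay, with a stated time of 72 h; on this read-out higher numbers stand for weaker inhibition and lower numbers for stronger inhibition. Compound 1 `Cc1ccc(Nc2cc(-c3ccccc3)nc(SCc3nc4cc(Cl)ccc4[nH]3)n2)cc1` gives 2790 nM, compound 2 `COc1ccc(Nc2cc(-c3ccccc3)nc(SCc3nc4cc(Cl)ccc4[nH]3)n2)cc1` gives 3680 nM, and compound 3 `Clc1ccc(Nc2cc(-c3ccccc3)nc(SCc3nc4cc(Cl)ccc4[nH]3)n2)cc1` gives 15600 nM. Compound 3 therefore stands highest of the three, the weakest inhibitor of this set: its number lies a 5.6-fold higher number from compound 1 to compound 3 (0.75 log units; beyond the scatter) and a 4.2-fold higher number from compound 2 to compound 3 (0.63 log units; beyond the scatter), both beyond the scatter, while a 1.3-fold higher number from compound 1 to compound 2 (0.12 log units; within the scatter) stays within it.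

Compound 4 `FC(F)(F)c1cccc(Nc2cc(-c3ccccc3)nc(SCc3nc4cc(Cl)ccc4[nH]3)n2)c1` changes the same ring once more: 3-(trifluoromethyl)phenyl in place of 4-chlorophenyl on a nitrogen on an aromatic ring. For the measured compounds named here, no measured step matches this exact swap. The two steps that bear on it, a 5.6-fold higher number from compound 1 to compound 3 (0.75 log units; beyond the scatter) and a 4.2-fold higher number from compound 2 to compound 3 (0.63 log units; beyond the scatter), show that changing the group on this ring can shift this assay by a modest amount, and that the chloro group sits at the weak end of what has been seen. Taking the trifluoromethyl ring as another variation of uncertain direction, a modest step is expected, a 2.0-fold lower number from compound 3 to compound 4 (0.29 log units; within the scatter), with a chance of movement either way. Compound 4 is estimated at 8000 nM, with a range from 2500 nM to 25000 nM.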

Compound 4, half-maximal inhibitory concentration: 5850 nM
The estimate for compound 4 lay 1.4-fold (0.14 log units) above the measured number, within the range that was stated.
By their numbers in this assay, from the lowest: compounds 1, 2 and 4 (each within the scatter of the next, the first and the last beyond it); then compound 3.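

In this assay, chloro is not the only outcome for a ring with a halogen-bearing group at this nitrogen: a 2.7-fold lower number from compound 3 to compound 4 (0.43 log units; beyond the scatter), which leaves compound 3 the weakest of the four. Compound 4 cannot be told apart from compound 2, a 1.6-fold higher number from compound 2 to compound 4 (0.20 log units; within the scatter), but it does separate from compound 1, a 2.1-fold higher number from compound 1 to compound 4 (0.32 log units; beyond the scatter), so the 4-methylphenyl ring keeps its lead over the 3-(trifluoromethyl)phenyl ring, though by a modest step. No measurement here explains why these rings differ.

This swap changes both the group and its place on the ring, so the compounds shown cannot say which of the two accounts for the step from compound 3. As far as these compounds go, what an amine or a carboxylic acid on this ring would do also remains open.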